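The source may hold more compounds than are shown below. What is called first, only, known or untested is meant among the compounds shown, and "the series" means these compounds.

Measured so far in a physicochemical assay for lipophilicity (a higher number here means a more lipophilic compound, a lower number a more polar compound), are three compounds
compound 1 `Clc1cccc(Cl)c1C1=NC(c2ccccc2)CO1` gives 3.69
compound 2 `Ic1ccccc1-c1ncco1` gives 2.3
compound 3 `CCOc1ccccc1C1=NC(c2ccccc2)CO1` gives 4.22

Compound 3 at 4.22 stands highest of the three, and both compound 1 and compound 2 lie lower, beyond the scatter. Compound 4 `COc1ccccc1C1=NC(c2ccccc2)CO1` departs from compound 3 in one place hydrogen in place of methyl on a saturated chain carbon bound to an oxygen on an aromatic ring with hydrogen in place of methyl on a saturated chain carbon bound to an oxygen on an aromatic ring, so ethoxy becomes methoxy. Going by the values given here, no measured pair shows this change, so the expectation rests on the structural change alone. A modest downward move in this assay is expected, probably just beyond the scatter. The estimate is a number 0.47 log units lower from compound 3 to compound 4 (beyond the scatter) in that direction. Compound 4 is expected at 3.75 with a range of 3.4 to 4.1 as its likely span.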

Compound 4, partition coefficient: 3.76
Compound 4: the middle estimate sits 0.01 log units below what was measured; low and high end bracket the measured number.
By their numbers in this assay, from the lowest: compound 2; then compounds 1 and 4 (each within the scatter of the next); then compound 3.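

Going by these compounds alone, this pair is the first in the set to differ in one place, so this assay can now be read for a single change: ethoxy becoming methoxy gives a number 0.46 log units lower from compound 3 to compound 4 (beyond the scatter). Removing one methyl from this chain on the shared core is therefore enough to produce a step beyond the scatter. Nothing measured here accounts for the size of that step.

Going by these compounds, whether a longer chain, such as propoxy, would extend this step in the opposite direction remains open. So does how a free hydroxyl or an amine in this place would compare.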